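The compounds below may be only part of what the source reports. "The series", "measured", "known", "first", "only" and "open" are said of these compounds alone.

Measured so far in a functional assay on RAW264.7 cells (Mus musculus) for inhibition, with a stated time of 30 min; on this read-out lower numbers stand for stronger inhibition and higher numbers for weaker inhibition:
compound 1 `C=C1C(=O)OC[C@@H]1CCOC(=O)Nc1ccc(C(C)C)cc1` gives 1580 nM;
compound 2 `C=C1C(=O)OC[C@H]1CCOC(=O)Nc1ccc(Br)cc1` gives 350 nM;
compound 3 `C=C1C(=O)OC[C@@H]1CCOC(=O)Nc1ccc(Br)cc1` gives 720 nM.

Compound 3 stands second highest of the three numbers, with compound 2 beyond the scatter on the lower side and compound 1 beyond the scatter on the higher side. Compound 4 `C=C1C(=O)OC[C@@H]1CCOC(=O)Nc1ccc(C(=O)OCCCC)cc1` differs from compound 3 by butoxycarbonyl in place of bromo on an aromatic carbon. Two measured steps are available. The exchange of the substituent on the same aromatic carbon gave a 2.2-fold lower number from compound 1 to compound 3 (0.34 log units; beyond the scatter), a modest move. The other, a 2.1-fold higher number from compound 2 to compound 3 (0.31 log units; beyond the scatter), rests on the fact that compounds 2 and 3 differ only in the configuration as drawn and does not concern the substituent. Exchanging the substituent on that carbon has so far shifted this assay only modestly, so a small move is expected. For compound 4 the expected step is a 1.3-fold higher number from compound 3 to compound 4 (0.10 log units; within the scatter). Compound 4 is estimated at 900 nM in this assay, within 350 nM to 2300 nM.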

Compound 4, half-maximal inhibitory concentration: 860 nM
Compound 4: the middle estimate sits 1.0-fold (0.02 log units) above what was measured, within the range that was stated.
By their numbers in this assay, from the lowest: compound 2; then compounds 3, 4 and 1 (each within the scatter of the next, the first and the last beyond it).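

Butoxycarbonyl in place of bromo on this aromatic carbon stays within the scatter in this assay, with a 1.2-fold higher number from compound 3 to compound 4 (0.08 log units; within the scatter), so the position accepts a far larger substituent than bromo without a readable shift. Against isopropyl the step also stays within the scatter, a 1.8-fold lower number from compound 1 to compound 4 (0.26 log units; within the scatter), which places butoxycarbonyl close to both groups, although these two stand beyond the scatter of each other. Nothing measured here bears on why this exchange behaves so.

Open, from the compounds shown here alone, is whether an amine, a carboxylic acid or a longer chain on this carbon would hold the number. Also open, going by these compounds, is whether butoxycarbonyl shows the same dependence on configuration as bromo.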